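The source may hold more compounds than are shown below. What is called first, only, known or untested is meant among the compounds shown, and "the series" means these compounds.

Measured compounds:
compound 1, `CCCCCCCCCCCCCCCC[Se]CCC(=O)NCc1ccc(O)c(OC)c1` — 4300 nM
compound 2, `CCCCC/C=C\C/C=C\CCCCCCCC[Se]CCC(=O)NCc1ccc(O)c(OC)c1` — 1400 nM
compound 3, `CCCCCCCC/C=C\CCCCCCCC[Se]CCC(=O)NCc1ccc(O)c(OC)c1` — 1800 nM

In an assay on HEK293 cells for antagonist activity at transient receptor potential cation channel subfamily V member 2 (Rattus norvegicus), read by fluorescence and calcium flux, with a stated time of 5 min (on this read-out higher numbers stand for weaker inhibition and lower numbers for stronger inhibition), compound 3 stands second highest of the three numbers. Its nearest neighbour is compound 2, with a 1.3-fold higher number from compound 2 to compound 3 (0.11 log units; within the scatter), so the two cannot be told apart. Its furthest is compound 1, and the step of a 2.4-fold lower number from compound 1 to compound 3 (0.38 log units; beyond the scatter) is modest but real; the related step of a 3.1-fold lower number from compound 1 to compound 2 (0.49 log units; beyond the scatter) is of the same kind. Both of these steps concern the shape of the long chain, not a polar substituent on it.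

Compound 4, `CCCCCC[C@@H](O)C/C=C\CCCCCCCC[Se]CCC(=O)NCc1ccc(O)c(OC)c1`, is made from compound 3 by the change (hydroxy in place of hydrogen on a saturated chain carbon bound to two saturated chain carbons). For the measured compounds named here, none of the measured steps bears on such a change: no compound among the three carries a hydroxy on the chain, and the only comparisons available are those between chains of differing saturation. What can be said is that the step from compound 2 to compound 3 was within the scatter, and that changes along this chain have so far moved the number by modest amounts at most. On that basis no step beyond the scatter is expected in this assay, in either direction. Compound 4 is therefore estimated at 1800 nM, with a range from 600 nM to 5400 nM. This estimate corresponds to an expected no change at the digits printed from compound 3 to compound 4 (within the scatter).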

Compound 4, half-maximal inhibitory concentration: > 10000 nM
Compound 4 was reported as a limit; the forecaster's own chance of this, stated with the estimate: 5%; middle value at least 5.5-fold (0.74 log units) away from the limit.
By their numbers in this assay, from the lowest: compounds 2 and 3 (each within the scatter of the next); then compound 1. At a limit, above all of these: compound 4.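

Compound 4 gives a limit of the assay rather than a number, and it is the only compound shown to do so: the limit of > 10000 nM in this assay, at which 1 of the 4 values shown sits.

The earlier compounds shown here differed only in the double bonds of the long chain, whereas here a single added oxygen, as hydroxy in place of hydrogen on a saturated chain carbon bound to two saturated chain carbons, gives an at least 5.5-fold higher number from compound 3 to compound 4 (0.74 log units; beyond the scatter) in this assay. The same reading also sets compound 4 apart beyond the scatter from both other compounds, with an at least 7.1-fold higher number from compound 2 to compound 4 (0.85 log units; beyond the scatter) and an at least 2.3-fold higher number from compound 1 to compound 4 (0.36 log units; beyond the scatter), so this place on the chain does not tolerate every change in this assay, and a hydroxy there costs inhibition.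

Going by these compounds, because the reading for compound 4 is a limit, the true size of these steps remains unknown. Also open, on these data alone, is whether the loss belongs to the hydroxy itself or to this place and its configuration, which a methoxy, a ketone or an amine on the same carbon, the opposite configuration of the alcohol, or a hydroxy elsewhere along the chain could address.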